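The compounds below may be only part of what the source reports. "The series", "measured", "known", "first", "only" and "open" are said of these compounds alone.

Compound 1 `COc1cc(-c2nn(-c3cccc(NC(=O)c4cccc(C(F)(F)F)c4)c3)cc2-c2ccncc2)ccc1Cl` and compound 2 `COc1cc(-c2nn(-c3cccc(NC(=O)Nc4ccc(Cl)c(C(F)(F)F)c4)c3)cc2-c2ccncc2)ccc1Cl` share a core and differ only where compound 2 carries (4-chloro-3-(trifluoromethyl)phenyl)amino in place of 3-(trifluoromethyl)phenyl on a carbonyl carbon. In a functional assay on SR cells (Homo sapiens) for inhibition, read by sulforhodamine B assay, with a stated time of 48 h (a lower number here means a stronger inhibitor of growth, a higher number a weaker inhibitor of growth), compound 1 gives 838 nM, and in this assay compound 2 gives 884 nM; the step of a 1.1-fold higher number from compound 1 to compound 2 (0.02 log units; within the scatter) leaves the two compounds indistinguishable within the scatter, so compound 2 stands level with compound 1 rather than apart from it.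

Compound 3 `O=C(Nc1cccc(-n2cc(-c3ccncc3)c(-c3ccc(Cl)c(O)c3)n2)c1)Nc1ccc(Cl)c(C(F)(F)F)c1` keeps everything of compound 2 except one change: hydrogen in place of methyl on an oxygen on an aromatic ring. Among the measured compounds shown here, no measured step touches this oxygen, so the pair of compounds 1 and 2 offers no direct guide, and the only lesson from it is that a single peripheral change left this assay unchanged within the scatter.

Compound 3 is therefore expected to show a 1.1-fold higher number from compound 2 to compound 3 (0.03 log units; within the scatter), a step not expected to exceed the scatter. The estimate for compound 3 in this assay is 950 nM, with a range from 400 nM to 2300 nM.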

Compound 3, concentration for 50% growth inhibition: 715 nM
The estimate for compound 3 lay 1.3-fold (0.12 log units) above the measured number, and the stated range covers the measured number.
By their numbers in this assay, from the lowest: compounds 3, 1 and 2 (each within the scatter of the next).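

The step from methoxy to hydroxy, the only one shown at this oxygen, gives in this assay a 1.2-fold lower number from compound 2 to compound 3 (0.09 log units; within the scatter). On this evidence, the methyl on the oxygen can give way to hydrogen without a change beyond the scatter, so the two compounds cannot be told apart here. Nothing at hand bears on the reason for this result.

The compounds shown leave open whether the position would accept other groups, since only methoxy and hydroxy appear there, and an ethoxy group, an amine or a carboxylic acid in that place could read differently. Going by these compounds, it is also open whether the same holds alongside the 3-(trifluoromethyl)phenyl on the carbonyl carbon, as hydroxy appears only with the (4-chloro-3-(trifluoromethyl)phenyl)amino group.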